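Dropping a methyl from the aromatic ring of compound 1

The source may report more compounds than this note shows. Statements on the series, on what has been measured and on what is new or still open speak of the compounds shown alone.

- compound 1 `CC[C@H](C)[C@@H]1C(=O)N[C@H](C2Cc3ccccc3C2)C(=O)N1[C@@H](C(=O)N1CCOCC1)c1cnc(C)cc1C` gives 1 mL.min-1.g-1 in an in vitro ADME assay on microsomes from liver (Homo sapiens) for metabolic stability; on this read-out higher numbers stand for fast clearance and lower numbers for slow clearance
- compound 2 `CC[C@H](C)[C@@H]1C(=O)N[C@H](C2Cc3ccccc3C2)C(=O)N1[C@@H](C(=O)NC)c1cnc(C)cc1C` gives 7 mL.min-1.g-1 in this assay

Compound 1 stands lowest of the two numbers in this assay. Within the data shown here, the one measured step is a 7.0-fold higher number from compound 1 to compound 2 (0.85 log units; beyond the scatter), a modest change beyond the scatter, made by methylamino in place of morpholin-4-yl on a carbonyl carbon.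

Compound 3 `CC[C@H](C)[C@@H]1C(=O)N[C@H](C2Cc3ccccc3C2)C(=O)N1[C@@H](C(=O)N1CCOCC1)c1ccc(C)nc1` keeps the morpholin-4-yl group of compound 1 and changes elsewhere: hydrogen in place of methyl on an aromatic carbon. In words, this is hydrogen in place of methyl on an aromatic carbon, taking 4,6-dimethylpyridin-3-yl to 6-methylpyridin-3-yl. Among the measured compounds shown here, no measured step touches this place, so the data give no direct guide to its size or direction. The step to compound 2 bears only as a scale for what one change has done in this series. With compound 1 at 1 mL.min-1.g-1, the lower of the two numbers, a small rise seems more likely than a fall.

The expected step is a 2.0-fold higher number from compound 1 to compound 3 (0.30 log units; within the scatter), upward and not clearly beyond the scatter. Compound 3 is expected at 2 mL.min-1.g-1, with an estimated range from 0.7 mL.min-1.g-1 to 6 mL.min-1.g-1.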

Compound 3, intrinsic clearance in microsomes: 3 mL.min-1.g-1
The estimate for compound 3 lay 1.5-fold (0.18 log units) below the measured number; the measured number falls inside the stated range.
By their numbers in this assay, from the lowest: compound 1; then compound 3; then compound 2.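

In this assay, hydrogen in place of methyl on the aromatic carbon ortho to a large group, taking 4,6-dimethylpyridin-3-yl to 6-methylpyridin-3-yl, gives a 3.0-fold higher number from compound 1 to compound 3 (0.48 log units; beyond the scatter), so this position does register on this read-out even though the change removes only a single carbon. With the morpholin-4-yl group held constant, this is a second place where one change from compound 1 raises the number, alongside a 7.0-fold higher number from compound 1 to compound 2 (0.85 log units; beyond the scatter), and compound 1 remains the lowest of the three compounds. No measurement at hand gives a reason for the rise at this position.

The compounds shown leave open whether the step at this aromatic carbon carries over when methylamino stands on the carbonyl carbon in place of morpholin-4-yl, and whether the two single changes would simply add. Also open, as far as these compounds go, is how this aromatic carbon behaves with substituents other than methyl and hydrogen, such as chlorine, methoxy or a nitrile, and whether any of them would hold the number as low as methyl does.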